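The source may report more compounds than this note shows. Statements on the series, on what has been measured and on what is new or still open speak of the compounds shown alone.

Compound 1 (`Oc1cccc2c1CCCC2c1c[nH]cn1`) is the reference point of this series. Going by the values given here, in an assay on isolated protein (Cricetulus griseus) for binding affinity to Alpha-1B adrenergic receptor (Mesocricetus auratus), read by radioligand binding (a higher number here means a weaker inhibitor, a lower number a stronger inhibitor), compound 1 gives 145 nM, and that is the only number among the values shown. Among the compounds with values here, compound 2 (`CC(c1cccc(NS(C)(=O)=O)c1)c1c[nH]cn1`) is the other compound measured so far. In this assay compound 2 gives < 10000 nM, which is a limit of the assay and not a number, as one of the two values shown sits at the limit of < 10000 nM in this assay, at which 1 of the 2 values shown sits. Compound 3 (`Nc1cccc2c1CCCC2c1c[nH]cn1`) has not yet been measured. It differs from compound 1 in one place, (amino in place of hydroxy on an aromatic carbon), the change sitting on an aromatic carbon of a six-membered aromatic ring of carbon only that is part of a fused system of two rings. Within the data shown here, no step between measured compounds is available to guide the expectation. The step of a 2.2-fold higher number from compound 1 to compound 3 (0.34 log units; beyond the scatter) is expected to be a modest loss, only a little beyond the scatter. Compound 3 is therefore estimated at 320 nM, within a range of 80 nM to 1500 nM.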

Compound 3, inhibition constant: 525 nM
Beside the measured number, compound 3's estimate is 1.6-fold (0.22 log units) below it; measured number inside the range.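

At this aromatic carbon, ortho to a fused ring and meta to a fused ring, amino in place of hydroxy gives a 3.6-fold higher number from compound 1 to compound 3 (0.56 log units; beyond the scatter) in this assay. The two groups match in the hydrogen-bond donors, acceptors and net charge counted for them, so these counts do not separate them, yet the number still moves beyond the scatter, and compound 3 keeps a measured value rather than a limit. Nothing among the data shown accounts for the size of this step.

The compounds shown leave open how a methoxy group, a methyl group or a fluorine atom on this carbon would compare with hydroxy and amino. They also leave open whether the same change would give a step of similar size at another aromatic carbon of the core.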